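The source may report more compounds than this note shows. Statements on the series, on what has been measured and on what is new or still open speak of the compounds shown alone.

Of the compounds shown here, three have been measured in an ADME assay on BHK cells (Mesocricetus auratus) for cytotoxicity, read by MTT assay, with a stated time of 96 h; a lower number here means that less compound is tolerated, a higher number that more compound is tolerated. Compound 1 `O=C(CN1CCCCC1)Nc1ccc(-c2nc3cc(C(F)(F)F)ccc3[nH]2)cc1` gives 12000 nM. Compound 2 `CCN(CC)CC(=O)Nc1ccc(-c2nc3cc(C(F)(F)F)ccc3n2C)cc1` gives 16000 nM, and compound 3 `CN1CCN(CC(=O)Nc2ccc(-c3nc4cc(C(F)(F)F)ccc4n3C)cc2)CC1` gives 16000 nM. Compound 3 stands level with compound 2, the two together at the higher end of the three numbers; compound 1 is the furthest from compound 3, and that gap too lies within the scatter, so the three numbers are not distinguishable.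

Compound 4 `Cn1c(-c2ccc(NC(=O)CN3CCCCC3)cc2)nc2cc(C(F)(F)F)ccc21` is the next compound. It differs from compound 3 in one place: piperidin-1-yl in place of 4-methylpiperazin-1-yl on a saturated chain carbon bound to a carbonyl carbon. Compound 1 already carries the piperidin-1-yl group on the same chain, with a different core, and its number sits in the same range as the others.

Within the data shown here, only one measured step exchanges the group on this chain carbon, no change at the digits printed from compound 2 to compound 3 (within the scatter), and it produced no change beyond the scatter. On that basis the step from compound 3 to compound 4 is also expected to stay within the scatter, a 1.1-fold lower number from compound 3 to compound 4 (0.06 log units; within the scatter). Compound 4 is therefore estimated to give 14000 nM in this assay, with a range from 7000 nM to 28000 nM.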

Compound 4, half-maximal cytotoxic concentration: > 100000 nM
Compound 4 ended at the assay's limit; the forecaster's own chance of this, stated with the estimate: 5%; middle value at least 7.1-fold (0.85 log units) away from the limit.
By their numbers in this assay, from the lowest: compounds 1, 2 and 3 (each within the scatter of the next). At a limit, above all of these: compound 4.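

In this assay, the group on a saturated chain carbon bound to a carbonyl carbon turns out to matter: piperidin-1-yl in place of 4-methylpiperazin-1-yl gives an at least 6.2-fold higher number from compound 3 to compound 4 (0.79 log units; beyond the scatter), and piperidin-1-yl in place of diethylamino gives an at least 6.2-fold higher number from compound 2 to compound 4 (0.79 log units; beyond the scatter), unlike the earlier exchange at this place, which gave no change at the digits printed from compound 2 to compound 3 (within the scatter). Piperidin-1-yl alone does not produce this, since it stands on both sides of an at least 8.3-fold higher number from compound 1 to compound 4 (0.92 log units; beyond the scatter), a step made by methyl in place of hydrogen on an aromatic nitrogen. Compound 4 sits at a limit of the assay, not at a number, so these three steps give only the smallest possible size: the limit of > 100000 nM in this assay, at which 1 of the 4 values shown sits.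

From the compounds shown here alone, whether other groups on this chain carbon behave the same way remains open, for example morpholin-4-yl or pyrrolidin-1-yl on the core of compound 4. Also open, going by these compounds, is how far the tolerated concentration of compound 4 lies beyond the limit.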